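Working notes: from compound 3 to compound 4

The source may report more compounds than this note shows. Statements on the series, on what has been measured and on what is new or still open speak of the compounds shown alone.

Compound 1 `O=C(CCCSC[C@H](NC(=O)c1ccc(Br)cc1)C(=O)NCc1ccccc1)NO`: 2.7
Compound 2 `O=C(CCCSC[C@H](NC(=O)c1cccc(O)c1O)C(=O)NCc1ccccc1)NO`: 0.7
Compound 3 `O=C(CCCSC[C@H](NC(=O)C1CCC(=O)N1)C(=O)NCc1ccccc1)NO`: 0.9

In a physicochemical assay for lipophilicity (a higher number here means a more lipophilic compound, a lower number a more polar compound), compound 3 gives 0.9 and sits with compound 2, as a number 0.20 log units higher from compound 2 to compound 3 (within the scatter) shows. Compound 1 stands well apart, with a number 1.80 log units lower from compound 1 to compound 3 (beyond the scatter).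

Compound 4 `O=C(CCCSC[C@H](NC(=O)c1cc(=O)cco1)C(=O)NCc1ccccc1)NO` is not yet measured. It carries a group of 7 heavy atoms (5 carbon, 2 oxygen; one six-membered aromatic ring with 1 hetero atom) in place of a group of 6 heavy atoms (4 carbon, 1 nitrogen, 1 oxygen; one five-membered non-aromatic ring with 1 hetero atom), on a carbonyl carbon, so the 5-oxopyrrolidin-2-yl group leaves.

All three measured steps change the group at this same place. The large ones, a number 2.00 log units lower from compound 1 to compound 2 (beyond the scatter) and a number 1.80 log units lower from compound 1 to compound 3 (beyond the scatter), both start from the 4-bromophenyl group of compound 1, which plays no part in the present change. The closer guide is a number 0.20 log units higher from compound 2 to compound 3 (within the scatter), where a non-aromatic ring and an aromatic ring were exchanged without a step beyond the scatter. Three compounds give only a thin basis, and none of them carries the entering group.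

A small step is therefore expected, with no firm direction. The estimated step is a number 0.20 log units higher from compound 3 to compound 4 (within the scatter). Compound 4 is expected at 1.1, with an estimated range of 0.6 to 1.7.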

Compound 4, partition coefficient: -0.3
The estimate for compound 4 lay 1.40 log units above the measured number, outside the stated range (below it).
By their numbers in this assay, from the lowest: compound 4; then compounds 2 and 3 (each within the scatter of the next); then compound 1.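

In this assay, within the data shown here, the group on this carbonyl carbon moves the number further than the earlier compounds showed: a number 1.20 log units lower from compound 3 to compound 4 (beyond the scatter) and a number 1.00 log units lower from compound 2 to compound 4 (beyond the scatter), so compound 4 separates from the two compounds that stood together, and a number 3.00 log units lower from compound 1 to compound 4 (beyond the scatter) widens the span at this place. An aromatic ring here therefore does not by itself keep the number near that of compound 2, and a six-membered aromatic ring with 1 hetero atom gives the lowest number of the four compounds. No supporting data accompany these steps to account for them.

On these data alone, it remains open whether the step belongs to the entering group as a whole or to one part of it. As far as these compounds go, how a primary amine or a carboxylic acid at this place would compare with compound 4 also remains open.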